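The source may hold more compounds than are shown below. What is called first, only, known or untested is meant among the compounds shown, and "the series" means these compounds.

The series rests on a shared core carrying a benzylamine arm. In a functional assay on cells for positive allosteric modulation of G-protein coupled receptor 68 (Homo sapiens), read by a luciferase reporter and cAMP accumulation, with a stated time of 30 min, at pH 6.8 and pH 8.3, in the presence of a further agent that is not named here (on this read-out lower numbers stand for lower potency and higher numbers for higher potency (the scale is a negative logarithm)), compound 1 `Nc1nc(NCc2ccccc2)nc(-c2ccccc2CO)n1` gives 4.35. Compound 2 `Cc1ccc(CNc2nc(N)nc(-c3ccccc3CO)n2)cc1` carries a methyl on the benzyl ring, and in this assay compound 2 gives 4.38. Among the measured compounds shown here, the only step measured so far, a number 0.03 log units higher from compound 1 to compound 2 (within the scatter), is methyl in place of hydrogen on an aromatic carbon and lies within the scatter, so on the two numbers at hand compound 2 stands at the higher figure but cannot be separated from compound 1.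

The next compound, compound 3 `Nc1nc(NCc2ccc(Oc3ccccc3)cc2)nc(-c2ccccc2CO)n1`, differs from compound 2 by phenoxy in place of methyl on an aromatic carbon. For the measured compounds named here, no measured step bears directly on this change: the one step known, from hydrogen to methyl, was flat, and the phenoxy group brings a second aromatic ring and an acceptor for which the two measured compounds give no guide. The expectation is therefore a modest rise at most, a number 0.22 log units higher from compound 2 to compound 3 (within the scatter), with wide uncertainty. Compound 3 is estimated at 4.6, within a range from 4 to 5.2.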

Compound 3, negative logarithm of the antagonist equilibrium constant: 5.19
Estimate against measurement, compound 3: 0.59 log units below, within the range that was stated.
By their numbers in this assay, from the lowest: compounds 1 and 2 (each within the scatter of the next); then compound 3.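

Phenoxy on this aromatic carbon gives a number 0.81 log units higher from compound 2 to compound 3 (beyond the scatter) in this assay, and set against the unsubstituted benzyl arm it gives a number 0.84 log units higher from compound 1 to compound 3 (beyond the scatter), so this position, where methyl could not be told from hydrogen, does respond to a change of group. The group that enters brings a six-membered aromatic ring of carbon only and a hydrogen-bond acceptor, neither of which methyl has, and compound 3 is the only one of the three set apart from the others. Nothing is available that explains the rise.

The compounds shown leave open whether the rise goes with the second ring or with the oxygen of phenoxy, a question on which methoxy and a directly attached phenyl would both bear. Also open, as far as these compounds go, is how the number would respond to a longer link such as benzyloxy, or to an amine or a carboxylic acid on the outer ring of phenoxy.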